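The compounds below may be only part of what the source reports. "The series", "measured", "known", "first", "only" and "open" are said of these compounds alone.

In an ADME assay on HEK-293T cells (Homo sapiens) for cytotoxicity, read by CCK-8 assay, with a stated time of 48 h (a lower number here means a stronger inhibitor, a higher number a weaker inhibitor), the measured compounds are:
Compound 1 `O=C(NCCNS(=O)(=O)c1ccc(-c2ccccc2O[C@H]2CC[C@H](O)CC2)s1)Nc1ccc([N+](=O)[O-])cc1`: 9000 nM
Compound 2 `O=[N+]([O-])c1ccc(NC(=S)NCCNS(=O)(=O)c2ccc(-c3ccccc3OCc3cccc(O)c3)s2)cc1`: > 20000 nM
Compound 3 `O=C(NCCNS(=O)(=O)c1ccc(-c2ccccc2O[C@H]2CC[C@H](O)CC2)s1)Nc1cc(Cl)cc(Cl)c1`: > 50000 nM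

Compound 3 stands at > 50000 nM, which is a limit and not a number. Compound 4 `O=[N+]([O-])c1ccc(NC(=S)NCCNS(=O)(=O)c2ccc(-c3ccccc3O[C@H]3CC[C@H](O)CC3)s2)cc1` differs from it on an amine nitrogen: a group of 12 heavy atoms (7 carbon, 2 nitrogen, 2 oxygen, 1 sulfur; one six-membered aromatic ring of carbon only) in place of a group of 11 heavy atoms (7 carbon, 1 nitrogen, 1 oxygen, 2 chlorine; one six-membered aromatic ring of carbon only), on an amine nitrogen. Compound 2 carries the same entering group and also gives only a limit, > 20000 nM. The measured step that bears most directly is an at least 5.5-fold higher number from compound 1 to compound 3 (0.74 log units; beyond the scatter), in which 3,5-dichlorophenyl replaced 4-nitrophenyl. Compound 4 has the 4-nitrophenyl again, so a step of similar size towards a lower number is expected in this assay. The expected step is an at least 4.5-fold lower number from compound 3 to compound 4 (0.65 log units; beyond the scatter). For compound 4 the estimate is 11000 nM, with an expected range from 4000 nM to 30000 nM.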

Compound 4, half-maximal inhibitory concentration: 10500 nM
The estimate for compound 4 lay 1.0-fold (0.02 log units) above the measured number, within the range that was stated.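

In this assay, putting sulfur for oxygen in the group on the amine nitrogen while keeping 4-nitrophenyl gives no readable change, with a 1.2-fold higher number from compound 1 to compound 4 (0.07 log units; within the scatter). The sulfur-bearing 4-nitrophenyl group also stands clearly apart from the 3,5-dichlorophenyl urea, with an at least 4.7-fold lower number from compound 3 to compound 4 (0.67 log units; beyond the scatter), a step that rests on a limit for compound 3. The step on the oxygen on the aromatic ring, an at least 1.9-fold lower number from compound 2 to compound 4 (0.27 log units; that floor lies within the scatter), also rests on a limit and cannot separate 4-hydroxycyclohexyl from 3-hydroxybenzyl.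

Going by these compounds, how a 4-aminophenyl or 4-cyanophenyl group would read in place of 4-nitrophenyl stays open. So does a 3,5-dichlorophenyl group on the sulfur-bearing link.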